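Working notes: naphthalen-2-yl to phenyl exchange

This account rests on a few compounds, and the source may have more. Where it says the series, first, only, none or still open, it means among the compounds named here.

In a functional assay for agonist activity, with Homo sapiens as the target (a higher number here means a weaker inhibitor, a lower number a stronger inhibitor), compound 1 (`O=C(O)CCC/C=C1/C[C@H]2C[C@@H](O)[C@H](/C=N/OCc3ccc4ccccc4c3)[C@H]2C1`) gives (2200 nM) and compound 2 (`O=C(O)CCC/C=C1\C[C@H]2C[C@@H](O)[C@H](/C=N\OC(c3ccccc3)c3ccccc3)[C@H]2C1`) gives (1600 nM). These two values lie within the scatter of each other, so compound 1 does not stand apart on the numbers available.

Compound 3 (`O=C(O)CCC/C=C1/C[C@H]2C[C@@H](O)[C@H](/C=N/OCc3ccccc3)[C@H]2C1`) carries phenyl in place of naphthalen-2-yl on a saturated chain carbon bound to an oxygen. For the measured compounds named here, no measured step covers this exchange, so the expectation rests only on the value of compound 1 (2200 nM) and the structural change. In this assay a small move toward a higher number is expected, possibly none beyond the scatter (a 1.4-fold higher number from compound 1 to compound 3 (0.13 log units; within the scatter)). For compound 3 the estimated value is (3000 nM), with an expected range from (800 nM) to (10000 nM).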

Compound 3, half-maximal inhibitory concentration: 5400 nM
Beside the measured number, compound 3's estimate is 1.8-fold (0.26 log units) below it, and the stated range covers the measured number.
By their numbers in this assay, from the lowest: compounds 2 and 1 (each within the scatter of the next); then compound 3.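

In this assay the exchange of naphthalen-2-yl for phenyl on a saturated chain carbon bound to an oxygen gives a 2.5-fold higher number from compound 1 to compound 3 (0.39 log units; beyond the scatter), a modest step beyond the scatter and the only one in the series that isolates a single place. This position is therefore not indifferent to the aryl group: in this one pair, the group with 10 heavy atoms and 2 aromatic rings goes with the lower number, and the group with 6 heavy atoms and one ring with the higher. Nothing available explains this step.

For the compounds shown here, compound 2 differs from compound 1 and compound 3 in more than one place, so it adds no second step at this position. Going by these compounds, whether a pyridine ring in place of the phenyl, or a longer chain carrying it, would bring the number back toward that of compound 1 remains open.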